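Removing one chloro from a fused core: two measured steps

A few compounds are considered here, and "the series" means these few. Any claim that something is new, unique, unknown or untested is made for them only; others in the source may bear on it.

Compound 1 `ClCc1cccc(Cn2cnc3c(Cl)ncnc32)c1`: in a functional assay on K562 cells (Homo sapiens) for cytotoxicity, read by sulforhodamine B assay, with a stated time of 48 h (a higher number here means a weaker inhibitor of growth, a lower number a stronger inhibitor of growth), compound 1 gives 15100 nM.
Compound 2 `ClCc1ccc(Cn2cnc3nc(Cl)nc(Cl)c32)cc1`: in this assay compound 2 gives only a limit, > 100000 nM.
Compound 3 `ClCc1cccc(Cn2cnc3c(Cl)nc(Cl)nc32)c1`: in this assay compound 3 likewise gives only a limit, > 100000 nM.

Within the data shown here, the one measured step, from compound 3 to compound 1, is hydrogen in place of chloro on an aromatic carbon. That change gave an at least 6.6-fold lower number from compound 3 to compound 1 (0.82 log units; beyond the scatter). Because the value of compound 3 is a limit, as noted in the limit of > 100000 nM in this assay, at which 2 of the 3 values shown sit, the true size of the step is not known; only its lower bound is.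

Compound 4 `ClCc1ccc(Cn2cnc3ncnc(Cl)c32)cc1` is not yet measured. Among the measured compounds shown here, its relation to compound 2 is hydrogen in place of chloro on an aromatic carbon, the same kind of change as the one from compound 3 to compound 1, and the two place descriptions are the same word for word. How the core of compound 2 differs from the core of compound 3 is not broken down here; the two have the same atoms joined differently, and both sit at the same limit in this assay.

Resting on the step from compound 3 to compound 1, the step from compound 2 to compound 4 is expected to be an at least 5.0-fold lower number from compound 2 to compound 4 (0.69 log units; beyond the scatter), with the caution that compound 2 is only a limit. Compound 4 is therefore estimated at 20000 nM, between 8000 nM and 80000 nM.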

Compound 4, concentration for total growth inhibition: > 100000 nM
Compound 4: a limit, no number; the forecaster's own chance of this, stated with the estimate: 20%; at least 5.0-fold (0.69 log units) between middle value and limit.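

In this assay compound 4 gives only a limit, > 100000 nM. Compound 2 is also only a limit, so no step from compound 2 to compound 4 can be read: the limit of > 100000 nM in this assay, at which 3 of the 4 values shown sit.

The compounds shown leave open whether hydrogen in place of chloro changes the growth inhibition of compound 2 at all, and by how much.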